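Shortening a Side Chain in an Endothelin Receptor Series

The source may report more compounds than this note shows. Statements on the series, on what has been measured and on what is new or still open speak of the compounds shown alone.

Of the compounds shown here, three sharing one core have so far been tested in an assay on VSM-A10 cells for antagonist activity at Endothelin-1 receptor (Rattus norvegicus); on this read-out higher numbers stand for weaker inhibition and lower numbers for stronger inhibition. Compound 1 `Cc1noc(N(CC(=O)O)S(=O)(=O)c2ccc(N)cc2)c1C` gives only a limit, > 32000 nM. Compound 1 thus sits at the limit of > 32000 nM in this assay, at which 1 of the 3 values shown sits. Compound 2 `Cc1noc(NS(=O)(=O)c2cccc3c(NCCCCCc4ccccc4)cccc23)c1C` gives 3050 nM, and compound 3 `Cc1noc(NS(=O)(=O)c2ccc3cc(N)ccc3c2)c1C` gives 660 nM. Of the two results that are real numbers rather than limits, compound 2 has the higher one, and the gap between compound 2 and compound 3 lies beyond the usual scatter of this assay.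

Compound 4 `CNc1cccc2c(S(=O)(=O)Nc3onc(C)c3C)cccc12` has not yet been measured. It differs from compound 2 in a single place: hydrogen in place of 4-phenylbutyl on a saturated chain carbon bound to a nitrogen on an aromatic ring. Within the data shown here, no pair of measured compounds differs by exactly this change, so its effect cannot be read off directly. Compound 3, the nearest measured neighbour, has a lower number than compound 2, but it differs from compound 2 in more than this one place, so it offers only a loose pointer. The step from compound 2 to compound 4 is therefore expected to be modest, a 1.5-fold lower number from compound 2 to compound 4 (0.18 log units; within the scatter), with the direction uncertain. Compound 4 is expected to give about 2000 nM, within a range from 500 nM to 8000 nM.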

Compound 4, half-maximal inhibitory concentration: 130 nM
Compound 4: middle estimate off by 15-fold (1.19 log units), on the high side; the measured number lies below the stated range.
By their numbers in this assay, from the lowest: compound 4; then compound 3; then compound 2. At a limit, above all of these: compound 1.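

This pair is the only one among the compounds shown that differs in a single place, so it gives the first direct reading of a change in this assay. Cutting the 5-phenylpentyl chain on the nitrogen on the aromatic ring back to methyl gives a 23-fold lower number from compound 2 to compound 4 (1.37 log units; beyond the scatter), so in this pair the long chain and its aromatic ring are not needed for inhibition, and carrying them goes with a much weaker result. The measured compounds offer no explanation for the size of this step.

This single pair cannot show whether the number climbs gradually as the chain grows or whether one part of the chain accounts for most of the step, a question that ethyl, propyl or an unbranched pentyl with no aromatic ring at its end could help to settle. It also leaves open whether a smaller group that still holds an aromatic ring, such as benzyl, or a chain ending in a carboxylic acid, would follow methyl or 5-phenylpentyl in this assay.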